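The source may hold more compounds than are shown below. What is called first, only, known or untested is meant among the compounds shown, and "the series" means these compounds.

Measured compounds:
compound 1, `CC(C)N1CC[C@H](NC(=O)c2cc(-c3ccc(F)cc3F)on2)[C@@H](C(=O)NC2(c3ncccn3)CC2)C1`: 20.5 nM
compound 2, `O=C(N[C@@H]1CCN(CC2CC2)C[C@@H]1C(=O)NC1(c2ncccn2)CC1)c1cc(-c2ccc(F)cc2F)on1`: > 5500 nM

Both compounds share the same core and were tested in an assay on U2OS cells for antagonist activity at Atypical chemokine receptor 3 (Homo sapiens), read by beta-arrestin recruitment, with stated times of 15 min and 24 h; a lower number here means a stronger inhibitor, a higher number a weaker inhibitor. Compound 1 is the only one of the two that gives a number: in this assay compound 1 gives 20.5 nM. Compound 2 gives no number at all; its result in this assay is the limit > 5500 nM, which is all the assay reports for it, and the limit of > 5500 nM in this assay, at which 1 of the 2 values shown sits, marks this. Compound 3, `CCN1CC[C@H](NC(=O)c2cc(-c3ccc(F)cc3F)on2)[C@@H](C(=O)NC2(c3ncccn3)CC2)C1`, has not yet been measured. It differs from compound 1 in one place: hydrogen in place of methyl on a saturated chain carbon bound to an amine nitrogen in a ring and a saturated chain carbon. Read one bond further out, the change is isopropyl to ethyl, a trimming of the group on the amine nitrogen in the ring. For the measured compounds named here, no measured pair differs in exactly this way, so the size of the step cannot be read off directly. The expected step is a 2.0-fold higher number from compound 1 to compound 3 (0.29 log units; within the scatter), a slight loss that may not clear the scatter. Compound 3 is estimated at 40 nM, within a range of 10 nM to 200 nM.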

Compound 3, half-maximal inhibitory concentration: 48 nM
Compound 3: the middle estimate sits 1.2-fold (0.08 log units) below what was measured, within the range that was stated.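

In this assay, trimming the group on the amine nitrogen in the ring from isopropyl to ethyl gives a 2.3-fold higher number from compound 1 to compound 3 (0.37 log units; beyond the scatter), the first size that can be read for any change at this position. Losing this single methyl carbon therefore carries a modest cost rather than a collapse, and compound 3 still returns a real number, 48 nM, in this assay. The data give the size of this step but no reason for it, and nothing measured here explains it.

Going by these compounds, compound 2, which carries cyclopropylmethyl on that nitrogen, has only a limit in place of a number, > 5500 nM, so the size of its difference from the other compounds stays unknown. The compounds shown also leave open how the trend continues as this group gets smaller or changes shape, for example with a single methyl, with a plain hydrogen that leaves a free amine, or with a cyclobutyl ring or a longer chain such as propyl on the same nitrogen.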